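From naphthalen-1-yl to 2,3-dihydro-1,4-benzodioxin-5-yl on the shared core

The compounds below may be only part of what the source reports. "The series", "measured", "known", "first", "only" and "open" are said of these compounds alone.

In an ADME assay on HFF cells (Homo sapiens) for cytotoxicity, read by resazurin assay, with a stated time of 96 h (a higher number here means that more compound is tolerated, a lower number that less compound is tolerated), so far, compound 1 `CN1CCN(c2ccc3nc(-c4ccc(-c5ccccc5)s4)c(-c4ccncc4)n3n2)CC1` gives 6800 nM and compound 2 `CN1CCN(c2ccc3nc(-c4cccc5ccccc45)c(-c4ccncc4)n3n2)CC1` gives 21300 nM as the higher of the two numbers. Compound 3 `CN1CCN(c2ccc3nc(-c4cccc5c4OCCO5)c(-c4ccncc4)n3n2)CC1` differs from compound 2 in one place, on an aromatic carbon of a five-membered aromatic ring with 2 nitrogen, next to the ring atom that bears a pyridin-4-yl group. The counted difference reads 2,3-dihydro-1,4-benzodioxin-5-yl in place of naphthalen-1-yl on an aromatic carbon and the rest of the structure stays the same. Within the data shown here, only one measured step bears on this place, a 3.1-fold higher number from compound 1 to compound 2 (0.50 log units; beyond the scatter) at the same aromatic carbon, modest but beyond the scatter. It shows that the number can move with the group here, but it involves neither the incoming group nor a comparable exchange, so the data set no direction. The expected step is a 1.1-fold higher number from compound 2 to compound 3 (0.05 log units; within the scatter) and no clear move beyond the scatter is anticipated. The estimate for compound 3 is 24000 nM with an expected range from 9000 nM to 55000 nM for this value.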

Compound 3, half-maximal cytotoxic concentration: > 50000 nM
Compound 3 ended at the assay's limit; the forecaster's own chance of this, stated with the estimate: 15%; middle value at least 2.0-fold (0.31 log units) from the limit.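

In this assay compound 3 stands at a limit of the assay, so its value is not an exact number: the limit of > 50000 nM in this assay, at which 1 of the 3 values shown sits.

Even so, the exchange of naphthalen-1-yl for 2,3-dihydro-1,4-benzodioxin-5-yl gives an at least 2.3-fold higher number from compound 2 to compound 3 (0.37 log units; beyond the scatter), which gives this aromatic carbon a direction that the earlier step alone could not: replacing one carbon-only aromatic ring with a non-aromatic ring holding two oxygen atoms goes with more compound being tolerated. The exchange of 5-phenylthiophen-2-yl for the same group gives an at least 7.3-fold higher number from compound 1 to compound 3 (0.86 log units; beyond the scatter), so among the three groups shown at this place, 2,3-dihydro-1,4-benzodioxin-5-yl tolerates the most compound, with both of its steps beyond the scatter.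

The full size of both steps stays unknown, and the compounds shown cannot separate the part played by the two oxygen atoms from that of the non-aromatic ring, a question that a 2-methoxyphenyl group or a 2,3-dihydrobenzofuran-7-yl group at this carbon would address. As far as these compounds go, it is also open whether the step holds when an amine other than the methylpiperazine of the shared core, such as morpholine, is present.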